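Naphthalen-1-yl for phenyl at the carbinol carbon

This account rests on a few compounds, and the source may have more. Where it says the series, first, only, none or still open, it means among the compounds named here.

Compound 2 `COc1ncc(-c2ccccc2)cc1[C@@H](c1ccccc1)[C@@](O)(CCN(C)C)c1ccccc1` gives 11.9 ug/mL in a toxicity assay on HeLa cells (Homo sapiens) for cytotoxicity (a lower number here means that less compound is tolerated, a higher number that more compound is tolerated), the lowest of the two numbers measured here. Among the measured compounds shown here, compound 1 `COc1ncc(-c2ccccc2)cc1[C@@H](c1ccccc1)[C@@](O)(CCN(C)C)c1cc(F)cc(F)c1` gives 28.8 ug/mL in this assay, and the single measured step, a 2.4-fold lower number from compound 1 to compound 2 (0.38 log units; beyond the scatter), is the only one. Compound 3 `COc1nc(-c2ccc(C(F)(F)F)cc2)ccc1[C@@H](c1ccccc1)[C@@](O)(CCN(C)C)c1cccc2ccccc12` gives only a limit in this assay, > 64 ug/mL, as noted in the limit of > 64 ug/mL in this assay, at which 1 of the 3 values shown sits; it is not a number.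

Compound 4 `COc1ncc(-c2ccccc2)cc1[C@@H](c1ccccc1)[C@@](O)(CCN(C)C)c1cccc2ccccc12` has not been measured. It differs from compound 2 by naphthalen-1-yl in place of phenyl on a saturated chain carbon bound to an oxygen on a saturated carbon and two saturated chain carbons. No measured step covers this exchange: the one step shown, from compound 1 to compound 2, concerns fluorine substitution on the same carbon and was of modest size. Compound 3 also carries naphthalen-1-yl at that carbon but differs from compound 4 elsewhere on the shared core, so its limit can be read only as what it shows.

For the measured compounds named here, with no direct step, the expectation for compound 4 is a step of a 2.4-fold higher number from compound 2 to compound 4 (0.37 log units; beyond the scatter) towards a higher number, weakly held. Compound 4 is therefore expected to give about 28 ug/mL in this assay, within a range from 10 ug/mL to 64 ug/mL, and a limit rather than a number would not be surprising.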

Compound 4, half-maximal cytotoxic concentration: 30.4 ug/mL
Beside the measured number, compound 4's estimate is 1.1-fold (0.04 log units) below it, within the range that was stated.
By their numbers in this assay, from the lowest: compound 2; then compounds 1 and 4 (each within the scatter of the next). At a limit, above all of these: compound 3.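

In this assay the exchange at this carbon now has a direct measurement on the shared core, with naphthalen-1-yl in place of phenyl: a 2.6-fold higher number from compound 2 to compound 4 (0.41 log units; beyond the scatter) (modest). The two groups that replace phenyl here, 3,5-difluorophenyl and naphthalen-1-yl, cannot be told apart, since the comparison of the two reads a 1.1-fold higher number from compound 1 to compound 4 (0.02 log units; within the scatter) and so leaves compound 2, with phenyl, alone at the low end of the three numbers on this core. Two different exchanges at this carbon thus end at the same level, although one adds only fluorine to the phenyl ring and the other brings a second six-membered aromatic ring of carbon only, and nothing shown bears on why the number moves at this position.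

Open, as far as these compounds go, is whether this level holds for other groups at this carbon, such as naphthalen-2-yl, cyclohexyl or a phenyl ring carrying a single fluorine. Also open, from the compounds shown here alone, is whether the step from phenyl to naphthalen-1-yl carries over to other cores, including that of compound 3, or to a longer chain in place of the dimethylamino side chain.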